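From Compound 1 to Compound 3: One Sulfonyl Group Exchanged

A few compounds are considered here, and "the series" means these few. Any claim that something is new, unique, unknown or untested is made for them only; others in the source may bear on it.

Among the compounds with values here, in a functional assay on HT-29 cells (Homo sapiens) for cytotoxicity, read by resazurin assay, with a stated time of 48 h (on this read-out lower numbers stand for an effect already at smaller amounts and higher numbers for an effect only at larger amounts of compound), compound 1 (`COc1ccc(S(=O)(=O)Nc2ccc(-c3nc4cc(NS(=O)(=O)c5ccc(OC)cc5)ccc4o3)cc2)cc1`) gives 40000 nM, the higher of the two numbers measured so far, while compound 2 (`O=S(=O)(Nc1ccc(-c2nc3cc(NS(=O)(=O)c4ccccc4Cl)ccc3o2)cc1)c1ccccc1Cl`) gives 15000 nM. Compound 3 (`COc1ccc(S(=O)(=O)Nc2ccc3oc(-c4ccc(NS(=O)(=O)c5cc(F)ccc5OC)cc4)nc3c2)cc1`) departs from compound 1 by 5-fluoro-2-methoxyphenyl in place of 4-methoxyphenyl on a sulfonyl sulfur, with 5-fluoro-2-methoxyphenyl in place of 4-methoxyphenyl on a sulfonyl sulfur. Within the data shown here, no measured pair isolates this change, so the expectation rests only on compound 1 standing at the top of a very small set. The estimated step is a 2.0-fold lower number from compound 1 to compound 3 (0.30 log units; within the scatter), a modest one toward a lower number in this assay. Compound 3 is expected at 20000 nM, within a range of 7000 nM to 50000 nM.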

Compound 3, half-maximal effective concentration: 15000 nM
Beside the measured number, compound 3's estimate is 1.3-fold (0.12 log units) above it; low and high end bracket the measured number.
By their numbers in this assay, from the lowest: compounds 2 and 3 (each within the scatter of the next); then compound 1.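

In this assay, within the data shown here, the exchange of 4-methoxyphenyl for 5-fluoro-2-methoxyphenyl on a sulfonyl sulfur gives a 2.7-fold lower number from compound 1 to compound 3 (0.43 log units; beyond the scatter), the only single-place change that can be read here, and it shows that the number responds to the group at this position. Nothing shown accounts for this step. The compounds leave open whether the fluorine or the shifted methoxy group carries the step, and how an amine or a carboxylic acid in place of the aryl group on that sulfur would read.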